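Urea series: chlorophenyl position swap on a second core

The source may report more compounds than this note shows. Statements on the series, on what has been measured and on what is new or still open speak of the compounds shown alone.

Compound 1 `CN(C)CCCNc1nc(-c2ccc(NC(=O)Nc3ccc(Cl)cc3)cc2)nc2c(Cl)c(Cl)sc12` and compound 2 `CN(C)CCCNc1nc(-c2ccc(NC(=O)Nc3ccccc3Cl)cc2)nc2c(Cl)c(Cl)sc12` share one core; compound 3 `CCN(CC)CCNc1nc(-c2ccc(NC(=O)Nc3ccc(Cl)cc3)cc2)nc2ccsc12` carries a different core, and the difference between the two cores is not broken down here. In a functional assay on MDA-MB-231 cells (Homo sapiens) for cytotoxicity, read by MTT assay, with a stated time of 72 h (on this read-out lower numbers stand for stronger inhibition and higher numbers for weaker inhibition), compound 1 gives 1160 nM and compound 2 gives 1560 nM. The change from compound 1 to compound 2 is 2-chlorophenyl in place of 4-chlorophenyl on an amide-type nitrogen and it made a 1.3-fold higher number from compound 1 to compound 2 (0.13 log units; within the scatter). In this assay compound 3 gives 550 nM, which stands beyond the scatter from both compound 1 and compound 2, so among the three measured compounds compound 3 shows the strongest inhibition.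

Compound 4 `CCN(CC)CCNc1nc(-c2ccc(NC(=O)Nc3ccccc3Cl)cc2)nc2ccsc12` is not yet measured. It differs from compound 3 by 2-chlorophenyl in place of 4-chlorophenyl on an amide-type nitrogen, the same change that was made from compound 1 to compound 2, at the same place. For compound 4 the step is expected to be a 1.3-fold higher number from compound 3 to compound 4 (0.12 log units; within the scatter), resting on the earlier step of a 1.3-fold higher number from compound 1 to compound 2 (0.13 log units; within the scatter) and on compound 3 at 550 nM. Compound 4 is estimated at 720 nM in this assay, between 350 nM and 1500 nM.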

Compound 4, half-maximal inhibitory concentration: 680 nM
Compound 4: middle estimate off by 1.1-fold (0.02 log units), on the high side; low and high end bracket the measured number.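

In this assay the swap of 4-chlorophenyl for 2-chlorophenyl on the amide-type nitrogen gives a 1.2-fold higher number from compound 3 to compound 4 (0.09 log units; within the scatter) on the core of compound 3, so on this core too the swap leaves the number within the scatter. The change therefore carries from one core to the other with no difference in the size of the step that these data can resolve: the same change on two cores in this assay, a 1.3-fold higher number (0.13 log units; within the scatter) from compound 1 to compound 2 and a 1.2-fold higher number (0.09 log units; within the scatter) from compound 3 to compound 4, 1.1-fold (0.04 log units) apart, within the scatter of two such steps. For the compounds shown here, this shows that the two chlorophenyl isomers can be treated as interchangeable on these two cores in this one cell assay, but it does not show that the same would hold on any further core or in another cell line, and with only two pairs it gives no reason for the result.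

The compounds shown leave open whether the ring on the urea tolerates more than a shift of its chlorine, for instance a plain phenyl or a methoxyphenyl in place of the chlorophenyl. Also open, going by these compounds, is whether the step stays as small with a morpholine in place of the dialkylamine at the chain end.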